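The source may hold more compounds than are shown below. What is called first, only, known or untested is meant among the compounds shown, and "the series" means these compounds.

Of the compounds shown here, three that share one core have been measured in a functional assay on cells (Cancer cell lines, Homo sapiens) for cytotoxicity, read by sulforhodamine B assay, with a stated time of 48 h; a higher number here means a weaker inhibitor of growth, a lower number a stronger inhibitor of growth. Compound 1 `COc1ccc(C2CC(c3ccccc3)=NN2C2=NC(=O)/C(=C3\C(=O)Nc4ccccc43)S2)cc1` gives 1520 nM. Compound 2 `COc1ccc(C2=NN(C3=NC(=O)/C(=C4\C(=O)Nc5ccccc54)S3)C(c3ccc(OC)cc3)C2)cc1` gives 100000 nM, the highest number of the three and so the weakest of this set. Compound 3 `COc1ccc(C2=NN(C3=NC(=O)/C(=C4\C(=O)Nc5ccc(Br)cc54)S3)C(c3ccc(OC)cc3)C2)cc1` gives 270 nM. The step from compound 1 to compound 2 was a 66-fold higher number from compound 1 to compound 2 (1.82 log units; beyond the scatter), and the step from compound 2 to compound 3 was a 370-fold lower number from compound 2 to compound 3 (2.57 log units; beyond the scatter).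

Compound 4 `COc1ccc(C2CC(c3ccc4ccccc4c3)=NN2C2=NC(=O)/C(=C3\C(=O)Nc4ccccc43)S2)cc1` differs from compound 2 by naphthalen-2-yl in place of 4-methoxyphenyl on a carbon with a double bond to nitrogen. The incoming naphthalen-2-yl carries no methoxy, so the change undoes the methoxy that sits on the group on a carbon with a double bond to nitrogen in compound 2 while enlarging that group. For the measured compounds named here, the one step that speaks to this is the methoxy addition from compound 1 to compound 2, which was a 66-fold higher number from compound 1 to compound 2 (1.82 log units; beyond the scatter); the bromo step concerns another part of the molecule and gives no guide. Reversing that methoxy addition is expected to bring the number down by a large step, a 50-fold lower number from compound 2 to compound 4 (1.70 log units; beyond the scatter). Compound 4 is therefore estimated at 2000 nM, with a range from 300 nM to 15000 nM.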

Compound 4, concentration for 50% growth inhibition: 360 nM
Beside the measured number, compound 4's estimate is 5.6-fold (0.74 log units) above it; the range from low to high includes it.
By their numbers in this assay, from the lowest: compounds 3 and 4 (each within the scatter of the next); then compound 1; then compound 2.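

Moving from 4-methoxyphenyl to naphthalen-2-yl on the carbon with a double bond to nitrogen in this assay gives a 280-fold lower number from compound 2 to compound 4 (2.44 log units; beyond the scatter), so a two-ring aromatic group with more heavy atoms is compatible with a low number here. Replacing phenyl at the same place gives a 4.2-fold lower number from compound 1 to compound 4 (0.63 log units; beyond the scatter), which shows that the second aromatic ring lowers the number further, though far less than removing 4-methoxyphenyl does. No measurement available here explains why these groups differ so sharply.

The compounds shown leave open whether a methyl or a dimethylamino group in place of the methoxy on that phenyl ring would also give a high number. They also leave open whether the bromo group seen in compound 3 would change the number when paired with naphthalen-2-yl.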